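This account rests on a few compounds, and the source may have more. Where it says the series, first, only, none or still open, it means among the compounds named here.

Three compounds of one series were tested in a functional assay on NCI-H23 cells (Homo sapiens) for cytotoxicity, read by sulforhodamine B assay, with a stated time of 48 h; on this read-out higher numbers stand for lower toxicity in this test and lower numbers for higher toxicity in this test. Compound 1 `ClCc1ccccc1Cn1cnc2c(Cl)nc(Cl)nc21` gives 6310 nM there, and compound 2 `ClCc1ccccc1Cn1cnc2c(Cl)ncnc21` gives 9330 nM. The two differ by one change, (hydrogen in place of chloro on an aromatic carbon), and the step it made is a 1.5-fold higher number from compound 1 to compound 2 (0.17 log units; within the scatter). Compound 3 `ClCc1ccc(Cn2cnc3nc(Cl)nc(Cl)c32)cc1` gives 8910 nM in this assay; how its core differs from the core of compound 1 is not broken down here, the two holding the same atoms joined differently. Compound 4 `ClCc1ccc(Cn2cnc3ncnc(Cl)c32)cc1` is not yet measured. It differs from compound 3 by hydrogen in place of chloro on an aromatic carbon, and the place of this change is described word for word as for the change from compound 1 to compound 2, so the same change is made a second time. Going by the values given here, on the strength of the one step seen, from compound 1 to compound 2 as a 1.5-fold higher number from compound 1 to compound 2 (0.17 log units; within the scatter), the step from compound 3 to compound 4 is expected to be a 1.5-fold higher number from compound 3 to compound 4 (0.16 log units; within the scatter), a small one lying within the scatter. Compound 4 is therefore estimated at 13000 nM, with the range 7000 nM to 25000 nM, in this assay.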

Compound 4, concentration lethal to 50% of the cells: 58900 nM
Compound 4: middle estimate off by 4.5-fold (0.66 log units), on the low side; the whole stated range lies below it.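

In this assay, hydrogen in place of chloro on the aromatic carbon between two ring nitrogen atoms gives a 6.6-fold higher number from compound 3 to compound 4 (0.82 log units; beyond the scatter) on the core of compound 3, so this change moves the number clearly there. Set beside the earlier step, the size of the change did not carry over from one core to the other: the same change on two cores in this assay, a 1.5-fold higher number (0.17 log units; within the scatter) from compound 1 to compound 2 and a 6.6-fold higher number (0.82 log units; beyond the scatter) from compound 3 to compound 4, 4.5-fold (0.65 log units) apart, beyond the scatter of two such steps. Going by these compounds alone, this shows that a step read on one core of this series is a poor guide to the size of the same step on the other, but with only two pairs it does not show what sets that size, since compound 1 and compound 3 hold the same atoms joined differently.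

The compounds shown leave open what happens when an amine or a methoxy group takes the place of that chloro group on either core. They also leave open whether the gap between the two steps persists when the chloromethyl group gives way to a longer chain or a carboxylic acid.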